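From a Butylphenyl to a Hydroxybenzyl Group

The compounds below may be only part of what the source reports. "The series", "measured", "known", "first", "only" and "open" are said of these compounds alone.

In a functional assay on MGC-803 cells (Homo sapiens) for antiproliferative activity, read by MTT assay, with a stated time of 72 h (a lower number here means a stronger inhibitor, a higher number a weaker inhibitor), compound 3 `CCCCc1ccc(Nc2nc(SCCC)nc3sc(Nc4ccccc4)nc23)cc1` gives 17400 nM, the smaller of the two numbers shown. Compound 1 `CCCSc1nc(Nc2ccccc2)c2nc(Nc3ccccc3)sc2n1` gives 24400 nM, and the step of a 1.4-fold lower number from compound 1 to compound 3 (0.15 log units; within the scatter) stays within the scatter. Compound 2 `CCCSc1nc(Nc2ccc(OC)cc2)c2nc(Nc3ccccc3)sc2n1` reaches only a limit here, > 64000 nM. Compound 4 `CCCSc1nc(NCc2ccc(O)cc2)c2nc(Nc3ccccc3)sc2n1` differs from compound 3 by 4-hydroxybenzyl in place of 4-butylphenyl on a nitrogen on an aromatic ring. Among the measured compounds shown here, two measured steps bear on this change: an at least 3.6-fold lower number from compound 2 to compound 3 (0.56 log units; beyond the scatter), where a butyl displaced a methoxy, and an at least 2.6-fold higher number from compound 1 to compound 2 (0.41 log units; beyond the scatter), where a methoxy entered. Compound 4 loses the butyl and gains a hydroxy, so a weaker result is expected because an at least 3.6-fold lower number from compound 2 to compound 3 (0.56 log units; beyond the scatter) ran the other way. Compound 4 is therefore expected near 45000 nM, within a range from 15000 nM to 130000 nM. For compound 4 this amounts to an expected step of a 2.6-fold higher number from compound 3 to compound 4 (0.41 log units; beyond the scatter).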

Compound 4, half-maximal inhibitory concentration: 21900 nM
Estimate against measurement, compound 4: 2.1-fold (0.31 log units) above; low and high end bracket the measured number.
By their numbers in this assay, from the lowest: compounds 3, 4 and 1 (each within the scatter of the next). At a limit, above all of these: compound 2.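

In this assay, 4-hydroxybenzyl on this nitrogen cannot be told apart from 4-butylphenyl, a 1.3-fold higher number from compound 3 to compound 4 (0.10 log units; within the scatter), or from phenyl, a 1.1-fold lower number from compound 1 to compound 4 (0.05 log units; within the scatter), so a group with a hydrogen-bond donor is accepted at this position. Only 4-methoxyphenyl stands apart, an at least 2.9-fold lower number from compound 2 to compound 4 (0.46 log units; beyond the scatter). Compound 2 gives a limit, not a number: the limit of > 64000 nM in this assay, at which 1 of the 4 values shown sits.

Going by these compounds, the hydroxy and the benzyl attachment enter together, so their separate contributions stay open. Also open, on these data alone, is whether a benzyl bearing an amine or a carboxylic acid, or a longer chain on this nitrogen, would give a similar number.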